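Swapping the aryl group on a highly soluble scaffold

A few compounds are considered here, and "the series" means these few. Any claim that something is new, unique, unknown or untested is made for them only; others in the source may bear on it.

Compound 1 `CCCS(=O)(=O)N1CCC(CNC(=O)c2c(F)cccc2F)(C(=O)N2CCOCC2)CC1` carries a shared core with a 2,6-difluorophenyl on its carbonyl carbon. In a physicochemical assay for solubility (a lower number here means a less soluble compound, a higher number a more soluble compound), compound 1 gives 10000 ug/mL. Two close relatives have been measured. Compound 2 `CCCS(=O)(=O)N1CCC(CNC(=O)c2c(F)ccc(Cl)c2F)(C(=O)N2CCOCC2)CC1` gives 10000 ug/mL, and compound 3 `CCCS(=O)(=O)N1CCC(CNC(=O)c2ccccc2OC(F)(F)F)(C(=O)N2CCOCC2)CC1` gives 10000 ug/mL. Compound 1 therefore stands level with both: the step of no change at the digits printed from compound 1 to compound 2 (within the scatter) and the step of no change at the digits printed from compound 1 to compound 3 (within the scatter) both stay within the scatter, as does no change at the digits printed from compound 2 to compound 3 (within the scatter).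

Compound 4 `CCCS(=O)(=O)N1CCC(CNC(=O)c2ccccc2Cl)(C(=O)N2CCOCC2)CC1` has not yet been measured. It differs from compound 1 in one place: 2-chlorophenyl in place of 2,6-difluorophenyl on a carbonyl carbon. For the measured compounds named here, the steps that bear on this are the aryl swaps already seen, no change at the digits printed from compound 1 to compound 3 (within the scatter) and no change at the digits printed from compound 2 to compound 3 (within the scatter), and the halogen addition no change at the digits printed from compound 1 to compound 2 (within the scatter), none of which moved the solubility beyond the scatter. A step of that same kind is expected here, so the change no change at the digits printed from compound 1 to compound 4 (within the scatter) is estimated to stay within the scatter. Compound 4 is therefore expected to give about 10000 ug/mL, with a likely range from 5000 ug/mL to 10000 ug/mL.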

Compound 4, solubility: 10000 ug/mL
Compound 4: the middle estimate sits on the measured number at the digits printed; measured number inside the range.
By their numbers in this assay, from the lowest: compounds 1, 2, 3 and 4 (each within the scatter of the next).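

The swap of 2,6-difluorophenyl for 2-chlorophenyl on this carbonyl carbon gives no change at the digits printed from compound 1 to compound 4 (within the scatter) in this assay and so adds a fourth aryl group to the series. Chloro in place of trifluoromethoxy on an aromatic carbon, a change the earlier compounds did not include, gives no change at the digits printed from compound 3 to compound 4 (within the scatter) and 2-chlorophenyl in place of 3-chloro-2,6-difluorophenyl gives no change at the digits printed from compound 2 to compound 4 (within the scatter) as well. All four compounds therefore stand level, and no aryl group shown at this position goes against that. Nothing measured here offers an explanation for this level result.

As far as these compounds go, whether a phenyl ring carrying an amine or a carboxylic acid, or a plain alkyl chain in place of the ring, would move the number at this carbonyl carbon stays open. The same holds for changes elsewhere on the shared core.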